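Methyl on the amide nitrogen of compound 2

A few compounds are considered here, and "the series" means these few. Any claim that something is new, unique, unknown or untested is made for them only; others in the source may bear on it.

compound 1 `CCCCNc1nc(N)nc2cccc(C(=O)N(C)C(C)C)c12`: > 25000 nM (a limit)
compound 2 `CCCCNc1nc(N)nc2cccc(C(=O)NCc3ccccc3)c12`: > 25000 nM (a limit)
compound 3 `CCCCNc1nc(N)nc2cccc(C(=O)N(C)Cc3ccccc3)c12`: not yet measured

In an ADME assay on HEK293 cells (Homo sapiens) for cytotoxicity, with a stated time of 6 h (on this read-out higher numbers stand for lower toxicity in this test and lower numbers for higher toxicity in this test), compound 2 stands at > 25000 nM which is a limit and not a number. Compound 3 carries methyl in place of hydrogen on an amide-type nitrogen. Among the measured compounds shown here, the one measured step (a step that the two limits leave unreadable from compound 1 to compound 2) has no readable size, and both values are limits (the limit of > 25000 nM in this assay, at which 2 of the 2 values shown sit). Compound 1 also bears a methyl on its amide-type nitrogen and shows > 25000 nM as a limit too. No step beyond the scatter is therefore expected in this assay for the estimated step (a step that the limit leaves unreadable from compound 2 to compound 3). For compound 3 the estimate is 30000 nM with an expected range of 15000 nM to 60000 nM and a report as a limit is likely.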

Compound 3, half-maximal cytotoxic concentration: > 25000 nM
Compound 3 gave a limit, no number (the forecaster's own chance of this, stated with the estimate: 85%); the middle value does not contradict the limit.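

No step can be read among compound 1, compound 2 and compound 3, since each value is a limit and not a number: the limit of > 25000 nM in this assay, at which 3 of the 3 values shown sit.

The compounds shown leave open whether methyl in place of hydrogen on the amide-type nitrogen changes the half-maximal cytotoxic concentration at all.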